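From Isopropyl to Phenyl on the Same Cyanoguanidine Core

The source may hold more compounds than are shown below. What is called first, only, known or untested is meant among the compounds shown, and "the series" means these compounds.

Of the compounds shown here, three built on one shared core have so far been tested in a functional assay on the whole organism (blood, strain Wistar-Okamoto) with Rattus norvegicus as the target, with a stated time of 5 days; on this read-out lower numbers stand for an effect already at smaller amounts and higher numbers for an effect only at larger amounts of compound. Compound 1 `N#CNC(=N)Nc1cccnc1`, the simplest of them, gives 50 mg/kg. Compound 2 `CC(C)/N=C(\NC#N)Nc1cccnc1` gives 2.5 mg/kg, the lowest number among the two values obtained; the gap between compound 2 and compound 1 lies well beyond the usual scatter of such measurements, so compound 2 is clearly the more potent of the two. Compound 3 `CCN(CC)CC/N=C(\NC#N)Nc1cccnc1` yields no number in this assay but only a limit, > 8 mg/kg.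

Compound 4 `N#CN/C(=N\c1ccccc1)Nc1cccnc1` has not yet been measured. It differs from compound 2 in one place: phenyl in place of isopropyl on a double-bonded nitrogen.

Among the measured compounds shown here, no measured pair in this set shows what this exchange does, so the expectation for compound 4 rests only on the two numbers available and on the change itself. In this assay, a rise in the number beyond the scatter is expected, that is, an effect only at somewhat larger amounts, amounting to a 4.0-fold higher number from compound 2 to compound 4 (0.60 log units; beyond the scatter). Compound 4 is therefore estimated at 10 mg/kg, with a likely range from 3 mg/kg to 40 mg/kg, and a real chance that the assay again reports only a limit.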

Compound 4, minimum effective dose: 5 mg/kg
For compound 4 the middle estimate is 2.0-fold (0.30 log units) above the measured one, within the range that was stated.
By their numbers in this assay, from the lowest: compounds 2 and 4 (each within the scatter of the next); then compound 1.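

In this assay, phenyl in place of isopropyl on a double-bonded nitrogen gives a 2.0-fold higher number from compound 2 to compound 4 (0.30 log units; within the scatter), so on this read-out the two groups cannot be told apart. Among the compounds shown here, this is the first direct look at what an exchange at this position does: a six-membered aromatic ring of carbon only can take the place of a group with no ring, and the effect in the whole animal stays within the usual spread of repeated measurements. The position therefore does not depend on isopropyl specifically, although a single pair of compounds shows this for one exchange only and sets no general rule.

What the compounds shown leave open is how this position responds to groups of a different kind, such as an amine, a carboxylic acid or a phenyl ring carrying a methoxy group, and whether any of them would move the number beyond the scatter. Compound 3 also cannot be ranked against the others, since its entry is a limit and not a number: the limit of > 8 mg/kg in this assay, at which 1 of the 4 values shown sits.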